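The compounds below may be only part of what the source reports. "The series", "measured", "known", "first", "only" and "open" are said of these compounds alone.

Working notes on the series. In a functional assay on MCF7 cells (Homo sapiens) for antiproliferative activity, with a stated time of 48 h (a lower number here means a stronger inhibitor, a higher number a weaker inhibitor), compound 1 (`Cc1cc(=O)c2c(O)cc(OC[C@H]3CO3)cc2o1`) gives 22900 nM and compound 2 (`Cc1cc(=O)c2c(O)cc(OC[C@@H]3CO3)cc2o1`) gives 36200 nM. The measured step is a 1.6-fold higher number from compound 1 to compound 2 (0.20 log units; within the scatter), so the two values stand level within the scatter. The relevant structural fact is the fact that compounds 1 and 2 differ only in the configuration as drawn.

Compound 3 (`Cc1cc(=O)c2c(OC[C@H]3CO3)cc(OC[C@@H]3CO3)cc2o1`) arises from compound 2 by one change: (oxiran-2-yl)methyl in place of hydrogen on an oxygen on an aromatic ring. In words, this is (oxiran-2-yl)methyl in place of hydrogen on an oxygen on an aromatic ring.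

Within the data shown here, the only measured step concerns configuration, not a substitution of this kind, so it sets no size for this change. As far as these compounds go, no step beyond the scatter is therefore expected in this assay, and the direction stays open. The estimated step is a 1.4-fold lower number from compound 2 to compound 3 (0.16 log units; within the scatter). Compound 3 is expected at 25000 nM, with an estimated range of 8000 nM to 80000 nM.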

Compound 3, half-maximal inhibitory concentration: 1880 nM
Compound 3: middle estimate off by 13-fold (1.12 log units), on the high side, and the stated range ends above it.
By their numbers in this assay, from the lowest: compound 3; then compounds 1 and 2 (each within the scatter of the next).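

In this assay, (oxiran-2-yl)methyl in place of hydrogen on an oxygen on an aromatic ring gives a 19-fold lower number from compound 2 to compound 3 (1.28 log units; beyond the scatter). Among these compounds, this is the first change to move the number beyond the scatter, whereas the configuration change in a 1.6-fold higher number from compound 1 to compound 2 (0.20 log units; within the scatter) does not, so this oxygen responds to substitution and its hydrogen is not needed to retain activity in this assay. Nothing known about the series bears on this substitution.

As far as these compounds go, it remains open whether the oxirane ring itself carries the step, or whether a plain methyl group or a longer alkyl chain on the same oxygen would give a step of similar size. From the compounds shown here alone, the effect of configuration at the newly introduced stereocentre also remains open.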